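Ring substituent swap on the benzyl arm: compound 4

The source may hold more compounds than are shown below. What is called first, only, known or untested is meant among the compounds shown, and "the series" means these compounds.

Three compounds of the series have numbers in an assay on isolated protein for displacement of a labelled ligand from D(4) dopamine receptor (Homo sapiens); on this read-out higher numbers stand for weaker inhibition and lower numbers for stronger inhibition. Compound 1 `O=C(NC1CCN(Cc2ccc(C(F)(F)F)cc2)CC1)c1cccc2ccccc12` gives 96 nM, compound 2 `COc1cccc(CN2CCC(NC(=O)c3cccc4ccccc34)CC2)c1` gives 168 nM, and compound 3 `O=C(NC1CCN(Cc2cccc(Br)c2)CC1)c1ccc2ccccc2c1` gives 36 nM. Compound 3 stands lowest of the three, with its nearest neighbour compound 1 beyond the scatter and compound 2 further off; note that compound 3 differs from compounds 1 and 2 in its core as well as in its benzyl arm, so only the benzyl change is followed here.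

Compound 4 `Cc1ccccc1CN1CCC(NC(=O)c2ccc3ccccc3c2)CC1` keeps the core of compound 3 and changes only the benzyl arm: 2-methylphenyl in place of 3-bromophenyl on a saturated chain carbon bound to an amine nitrogen in a ring. Among the measured compounds shown here, the one measured step of comparable kind is a 1.8-fold higher number from compound 1 to compound 2 (0.24 log units; within the scatter), where a different pair of ring substituents was exchanged at the same place without moving the number beyond the scatter. For the measured compounds named here, no measured step addresses a bromine-to-methyl exchange or a change of substituent position directly. On that basis the step of a 1.7-fold higher number from compound 3 to compound 4 (0.22 log units; within the scatter) is expected to stay near the scatter, with a slight lean toward a higher number given the smaller substituent entering. Compound 4 is therefore estimated at 60 nM, within 20 nM to 180 nM.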

Compound 4, inhibition constant: 26 nM
Beside the measured number, compound 4's estimate is 2.3-fold (0.36 log units) above it; low and high end bracket the measured number.
By their numbers in this assay, from the lowest: compounds 4 and 3 (each within the scatter of the next); then compounds 1 and 2 (each within the scatter of the next).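

In this assay the exchange of 3-bromophenyl for 2-methylphenyl, on a saturated chain carbon bound to an amine nitrogen in a ring, gives a 1.4-fold lower number from compound 3 to compound 4 (0.14 log units; within the scatter) and so adds a second step at this place that stays within the scatter, now on the core of compound 3 rather than on that of compound 1. The substituent and its position on the ring change together in this one step, yet the number does not move beyond the scatter, so on this core the bromine is not required to keep the number at this level. No available observation accounts for this outcome.

Because substituent and position change together, the step cannot show what either change does alone, and the two may offset each other. As far as these compounds go, both arms in this step count no hydrogen-bond donors or acceptors and carry no net charge, so it remains open how the number responds to a carboxylic acid or an amine on the ring, or to a longer chain in place of the saturated chain carbon.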